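This account rests on a few compounds, and the source may have more. Where it says the series, first, only, none or still open, it means among the compounds named here.

Of the compounds shown here, three built on one shared core have been tested in an in vitro functional assay on cells for agonist activity at Bombesin receptor subtype-3 (Homo sapiens), read by luminescence and calcium flux; on this read-out lower numbers stand for an effect already at smaller amounts and higher numbers for an effect only at larger amounts of compound. Compound 1 `O=C(O)c1ccccc1-c1ccc(CCc2ncc(CC3CCCCC3)[nH]2)cc1` carries a cyclohexyl on a saturated chain carbon bound to an aromatic carbon, and in this assay compound 1 gives 41 nM. Compound 2 `COc1ccc(Cc2cnc(CCc3ccc(-c4ccccc4C(=O)O)cc3)[nH]2)cc1` carries a 4-methoxyphenyl at the same place, and in this assay compound 2 gives 5360 nM. Compound 3 `O=C(O)c1ccccc1-c1ccc(CCc2ncc(Cc3cccc(F)c3)[nH]2)cc1` carries a 3-fluorophenyl there, and in this assay compound 3 gives 159 nM, the second highest of the three numbers: a 3.9-fold higher number from compound 1 to compound 3 (0.59 log units; beyond the scatter), while a 34-fold lower number from compound 2 to compound 3 (1.53 log units; beyond the scatter).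

Compound 4 `CCC(C)(CC)Cc1cnc(CCc2ccc(-c3ccccc3C(=O)O)cc2)[nH]1` differs from compound 3 in one place: 1-ethyl-1-methylpropyl in place of 3-fluorophenyl on a saturated chain carbon bound to an aromatic carbon. Among the measured compounds shown here, two measured steps bear on this change. The first is a 3.9-fold higher number from compound 1 to compound 3 (0.59 log units; beyond the scatter); the second is the large step of a 130-fold higher number from compound 1 to compound 2 (2.12 log units; beyond the scatter). Both show that the cyclohexyl, a saturated group, went with the lowest number of the three, and that the two aromatic groups went with higher numbers. The incoming 1-ethyl-1-methylpropyl is saturated too, though it has no ring, so a step back toward the number of compound 1 is expected. Compound 4 is therefore expected to give 50 nM, with a range from 15 nM to 200 nM. That estimate means an expected step of a 3.2-fold lower number from compound 3 to compound 4 (0.50 log units; beyond the scatter).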

Compound 4, half-maximal effective concentration: 76 nM
Compound 4: middle estimate off by 1.5-fold (0.18 log units), on the low side; low and high end bracket the measured number.
By their numbers in this assay, from the lowest: compounds 1 and 4 (each within the scatter of the next); then compound 3; then compound 2.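

At this position a ring is not needed for a low number in this assay: with the open-chain 1-ethyl-1-methylpropyl in place of the cyclohexyl, the step is a 1.9-fold higher number from compound 1 to compound 4 (0.27 log units; within the scatter) and the two groups cannot be told apart. Among the compounds shown here, the same open-chain group stands clear of both aromatic groups, with a 2.1-fold lower number from compound 3 to compound 4 (0.32 log units; beyond the scatter) and the far larger a 71-fold lower number from compound 2 to compound 4 (1.85 log units; beyond the scatter), so across these four compounds the two saturated groups go with the low numbers and the two aromatic groups with the higher ones, and no compound goes against that split. No measurement at hand explains why the saturated and aromatic groups part in this way.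

The compounds shown leave open whether other saturated groups, such as cyclopentyl or tert-butyl, or a ring that carries an amine, such as piperidinyl, would also give numbers this low. They also leave open how much of the wide gap between the two aromatic groups comes from the fluorine, the methoxy group or where each sits on the ring, and an unsubstituted phenyl would be the plain reference for that question.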